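Phenyl in Place of Thiophen-3-yl on a Shared Core

This account rests on a few compounds, and the source may have more. Where it says the series, first, only, none or still open, it means among the compounds named here.

Compound 1 `Nc1nc(N)c2c(-c3ccsc3)cn([C@@H]3O[C@H](CO)[C@@H](O)[C@H]3O)c2n1` was tested in a functional assay on HCT-116 cells (Homo sapiens), read by MTT assay, with a stated time of 72 h; a lower number here means a stronger inhibitor, a higher number a weaker inhibitor. In this assay compound 1 gives > 20000 nM, which is a limit of the assay rather than a number. For the measured compounds named here, compound 2 `C#Cc1cn([C@@H]2O[C@H](CO)[C@@H](O)[C@H]2O)c2ncnc(NC)c12` is the only other measured compound. In this assay compound 2 gives > 20000 nM, again a limit. Going by the values given here, both results sit at the same place, as the limit of > 20000 nM in this assay, at which 2 of the 2 values shown sit, shows, so compound 1 cannot be ranked against anything, and no step between measured compounds exists. Compound 3 `Nc1nc(N)c2c(-c3ccccc3)cn([C@@H]3O[C@H](CO)[C@@H](O)[C@H]3O)c2n1` differs from compound 1 in one way: phenyl in place of thiophen-3-yl on an aromatic carbon. Among the compounds with values here, no measured step gauges this change. Because compound 1 gives > 20000 nM, a large gain is not expected. The expected step that the limit leaves unreadable from compound 1 to compound 3 therefore means no movement beyond the scatter. The estimate for compound 3 is 30000 nM, in a range from 10000 nM to 100000 nM.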

Compound 3, half-maximal inhibitory concentration: > 20000 nM
Compound 3 gave a limit, no number; the forecaster's own chance of this, stated with the estimate: 75%; the middle value lies beyond the limit too.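

Compound 1 and compound 3 both end at the assay limit, so no step between them can be read: the limit of > 20000 nM in this assay, at which 3 of the 3 values shown sit.

The compounds shown leave open whether phenyl and thiophen-3-yl differ at all on the shared core, and what actual value any of them would reach in this assay.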